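Hydroxyphenyl positional isomers on a shared core: cytotoxicity notes

The compounds below may be only part of what the source reports. "The series", "measured", "known", "first", "only" and "open" are said of these compounds alone.

Measured so far:
compound 1 `Oc1ccc(-c2cc(-c3ccc(O)cc3)nc(-c3ccc(O)cc3)c2)cc1` 790 nM
compound 2 `Oc1ccc(-c2cc(-c3cccc(O)c3)nc(-c3cccc(O)c3)c2)cc1` 730 nM
compound 3 `Oc1ccccc1-c1cc(-c2ccccc2O)nc(-c2ccccc2O)c1` 140 nM

In an ADME assay on HEK293 cells (Homo sapiens) for cytotoxicity, read by CCK-8 assay, with a stated time of 4 days (on this read-out higher numbers stand for weaker inhibition and lower numbers for stronger inhibition), compound 1 stands at the highest number of the three. The gap to compound 2 lies within the scatter of the method; the gap to compound 3 lies beyond it, compound 3 giving the stronger inhibition.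

Compound 4 `Oc1ccc(-c2cc(-c3cccc(O)c3)cc(-c3ccc(O)cc3)n2)cc1` is not yet measured. It differs from compound 1 by 3-hydroxyphenyl in place of 4-hydroxyphenyl on an aromatic carbon. Compound 2 carries 3-hydroxyphenyl groups and sits within the scatter of compound 1, so the step from compound 1 to compound 4 in this assay is expected to be none beyond the scatter, a 1.1-fold lower number from compound 1 to compound 4 (0.02 log units; within the scatter). For compound 4 the estimate in this assay is 750 nM, with a range of 350 nM to 1600 nM.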

Compound 4, half-maximal inhibitory concentration: > 50000 nM
Compound 4 ended at the assay's limit; the forecaster's own chance of this, stated with the estimate: 3%; middle value at least 66-fold (1.82 log units) away from the limit.
By their numbers in this assay, from the lowest: compound 3; then compounds 2 and 1 (each within the scatter of the next). At a limit, above all of these: compound 4.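

In this assay, 3-hydroxyphenyl in place of 4-hydroxyphenyl on the aromatic carbon opposite the ring nitrogen gives an at least 63-fold higher number from compound 1 to compound 4 (1.80 log units; beyond the scatter), a step made with the same atoms joined differently. Compound 4 stands at a limit of the read-out, > 50000 nM, and not at a number. This position therefore responds to where the hydroxyl sits on its ring, and the size of the step is bounded only by that limit: the limit of > 50000 nM in this assay, at which 1 of the 4 values shown sits.

Going by these compounds, how far compound 4 lies past the limit stays open. Also open, on these data alone, is whether an amine or a carboxylic acid in place of the hydroxyl at this position would behave like either isomer.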